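A few compounds are considered here, and "the series" means these few. Any claim that something is new, unique, unknown or untested is made for them only; others in the source may bear on it.

Compound 3 `c1ccc(-c2nc3ncccn3c2CN2CCCCC2)cc1` gives 30 nM in a functional assay on MDA-MB-231 cells (Homo sapiens) for inhibition, read by sulforhodamine B assay, with a stated time of 48 h; a higher number here means a weaker inhibitor of growth, a lower number a stronger inhibitor of growth. It stands level with compound 1 `Cc1ccn2c(CN3CCCCC3)c(-c3ccccc3)nc2n1`, which gives 30 nM, and the two are together the lowest of the three numbers; compound 2 `c1ccc(-c2nc3ncccn3c2CN2CCCC2)cc1` gives 70 nM. The two measured steps are small: no change at the digits printed from compound 1 to compound 3 (within the scatter) and a 2.3-fold lower number from compound 2 to compound 3 (0.37 log units; beyond the scatter). Compound 4 `c1ccc(-c2nc3ncccn3c2CN2CCNCC2)cc1` differs from compound 3 in one place: piperazin-1-yl in place of piperidin-1-yl on a saturated chain carbon bound to an aromatic carbon. Within the data shown here, neither measured step exchanges a ring carbon of the saturated ring for a nitrogen, so there is no direct precedent; the ring-size step a 2.3-fold lower number from compound 2 to compound 3 (0.37 log units; beyond the scatter) shows only that this assay tolerates changes at this position modestly. A step of a 2.0-fold higher number from compound 3 to compound 4 (0.30 log units; within the scatter) is therefore expected, and compound 4 is estimated at 60 nM, between 20 nM and 200 nM.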

Compound 4, concentration for 50% growth inhibition: 26700 nM
Compound 4: middle estimate off by 450-fold (2.65 log units), on the low side; the whole stated range lies below it.
By their numbers in this assay, from the lowest: compounds 1 and 3 (each within the scatter of the next); then compound 2; then compound 4.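

The change from piperidin-1-yl to piperazin-1-yl costs far more in this assay (an 890-fold higher number from compound 3 to compound 4 (2.95 log units; beyond the scatter)) than the ring-size step suggested, and the change from pyrrolidin-1-yl is similarly large (a 380-fold higher number from compound 2 to compound 4 (2.58 log units; beyond the scatter)). This position therefore tolerates some change in ring size but not this exchange, even though the ring stays six-membered and the heavy-atom count is unchanged. Nothing available explains the loss.

As far as these compounds go, it remains open whether the loss follows the second ring nitrogen itself or the hydrogen it carries. A morpholine ring, or a piperazine with a methyl on that nitrogen, would separate the two.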